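Swapping a carboxylic acid for an acetoxymethyl on a furan

The source may report more compounds than this note shows. Statements on the series, on what has been measured and on what is new or still open speak of the compounds shown alone.

Measured compounds, all tested in a functional assay on A549 cells (Homo sapiens) for cytotoxicity, read by MTT assay, with a stated time of 72 h; on this read-out lower numbers stand for an effect already at smaller amounts and higher numbers for an effect only at larger amounts of compound:
- Compound 1 `CCc1cccc2c(O)c(-c3occ(C)c3C(=O)O)ccc12` gives 10.6 ug/mL.
- Compound 2 `CCOc1c(-c2occ(C)c2C(=O)O)ccc2c(CC)cccc12` reaches only the limit > 10 ug/mL, which is a boundary of the assay rather than a number.
- Compound 3 `CCc1cccc2c(OC)c(-c3occ(C)c3C(=S)OC)ccc12` gives 6.2 ug/mL.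

Compound 2 therefore stands at the upper edge of what this assay can resolve, as summarized by the limit of > 10 ug/mL in this assay, at which 1 of the 3 values shown sits. Going by the values given here, the only step among the measured compounds that touches it is a step that the limit leaves unreadable from compound 1 to compound 2, which that limit leaves unreadable, so no measured step tells how large a single change near this position can be.

Compound 4 `CCOc1c(-c2occ(C)c2COC(C)=O)ccc2c(CC)cccc12` differs from compound 2 by acetoxymethyl in place of carboxy on an aromatic carbon. Among the compounds with values here, no measured pair shows this exact change; compound 3, which likewise lacks the free carboxy, gives a number within the assay's window, while compound 2 gives only a limit. On that thin basis a modest move toward smaller numbers is expected, an at least 1.2-fold lower number from compound 2 to compound 4 (0.09 log units; that floor lies within the scatter), though it may well stay within the scatter. Compound 4 is estimated at 8 ug/mL, with a likely range from 3 ug/mL to 25 ug/mL.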

Compound 4, concentration for half-maximal effect: > 10 ug/mL
Compound 4: a limit, no number; the forecaster's own chance of this, stated with the estimate: 40%; middle value at least 1.2-fold (0.09 log units) from the limit.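

Going by these compounds alone, compound 2 and compound 4 both end at a limit rather than a number in this assay, so no step between them can be read: the limit of > 10 ug/mL in this assay, at which 2 of the 4 values shown sit. The compounds shown leave open whether acetoxymethyl in place of carboxy changes the result in this assay at all.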